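Swapping fluoro for trifluoromethyl on compound 2

This account rests on a few compounds, and the source may have more. Where it says the series, first, only, none or still open, it means among the compounds named here.

Values in a functional assay on MOLT-4 cells (Homo sapiens) for inhibition, read by MTT assay, with a stated time of 72 h; on this read-out higher numbers stand for weaker inhibition and lower numbers for stronger inhibition:
- compound 1: 186000 nM
- compound 2: 24000 nM

Compound 1 `COc1cc(NC(C)CCCNC(=O)NNC(=O)Nc2ccc(Cl)cc2)c2ncccc2c1` and compound 2 `COc1cc(NC(C)CCCNC(=O)Nc2ccc(F)cc2)c2ncccc2c1` are the only two measured so far, and compound 2 has the lower number, making it the stronger inhibitor of the pair. Going by the values given here, the one measured step is a 7.8-fold lower number from compound 1 to compound 2 (0.89 log units; beyond the scatter), a modest move beyond the scatter.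

Compound 3 `COc1cc(NC(C)CCCNC(=O)Nc2ccc(C(F)(F)F)cc2)c2ncccc2c1` is compound 2 with one group changed: trifluoromethyl in place of fluoro on an aromatic carbon. Trifluoromethyl takes the place of fluoro on an aromatic carbon, para to a large group.

The measured step replaced a different group, so no data yet compare fluoro with trifluoromethyl directly. That step serves only as a rough guide to how far values can move among these compounds. The swap here is smaller in scope, so a small shift towards a lower number is expected in this assay, probably not beyond the scatter. The expected change is a 1.5-fold lower number from compound 2 to compound 3 (0.18 log units; within the scatter). For compound 3 the estimated value is 16000 nM, with an expected range from 6000 nM to 45000 nM.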

Compound 3, half-maximal inhibitory concentration: 20000 nM
Compound 3: the middle estimate sits 1.3-fold (0.10 log units) below what was measured; the measured number falls inside the stated range.
By their numbers in this assay, from the lowest: compounds 3 and 2 (each within the scatter of the next); then compound 1.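

In this assay, trifluoromethyl on an aromatic carbon, para to a large group, reads much the same as fluoro: the change, from one heavy atom to four, gives a 1.2-fold lower number from compound 2 to compound 3 (0.08 log units; within the scatter) and so cannot be told apart from repeat-measurement noise. Putting 4-(trifluoromethyl)phenyl in place of ((4-chlorophenyl)carbamoyl)amino on the amide-type nitrogen gives a 9.3-fold lower number from compound 1 to compound 3 (0.97 log units; beyond the scatter), so the separation from compound 1 seen with 4-fluorophenyl in a 7.8-fold lower number from compound 1 to compound 2 (0.89 log units; beyond the scatter) is also seen with this second group. The data offer nothing that explains why fluoro and trifluoromethyl read alike here, or why compound 1 stands apart.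

Both groups compared at this position contain fluorine, so the compounds shown leave open whether an amine, a carboxylic acid or a hydroxyl group there would move the number beyond the scatter. Also open, going by these compounds, is how a longer chain linking the shared core to the amide-type nitrogen would read in this assay when paired with either 4-fluorophenyl or 4-(trifluoromethyl)phenyl.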